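Swapping the acetylpiperidine for a methylpyridine

The compounds below may be only part of what the source reports. "The series", "measured", "known", "first", "only" and "open" are said of these compounds alone.

Measured so far in a physicochemical assay for lipophilicity, using the shake flask method, in phosphate buffer, measured as octanol-water partition, with a stated time of 30 min, at pH 7.4; a lower number here means a more polar compound, a higher number a more lipophilic compound:
compound 1 `Cc1nccn1-c1cnc(NCc2c(F)ccc3c2CCO3)c2cn[nH]c(=O)c12` gives 2.1;
compound 2 `CN(C)C(=O)c1cc(-c2cnc(NCc3c(F)ccc4c3CCO4)c3cn[nH]c(=O)c23)n(C)n1` gives 2.1;
compound 3 `CC(=O)N1CCC(c2cnc(NCc3c(F)ccc4c3CCO4)c3cn[nH]c(=O)c23)CC1` gives 2.9.

Compound 3 stands highest of the three, since the steps of a number 0.80 log units higher from compound 1 to compound 3 (beyond the scatter) and a number 0.80 log units higher from compound 2 to compound 3 (beyond the scatter) both go beyond the scatter, while no change at the digits printed from compound 1 to compound 2 (within the scatter). Compound 4 `Cc1ncccc1-c1cnc(NCc2c(F)ccc3c2CCO3)c2cn[nH]c(=O)c12` differs from compound 3 in one place: 2-methylpyridin-3-yl in place of 1-acetylpiperidin-4-yl on an aromatic carbon. Both steps that end at compound 3 replace a five-membered aromatic ring with the 1-acetylpiperidin-4-yl group and rise by a modest amount, but no measured step brings in the 2-methylpyridin-3-yl group, so its effect is not shown directly. A small step of a number 0.10 log units higher from compound 3 to compound 4 (within the scatter) is therefore expected in this assay, within or near the scatter. Compound 4 is estimated at 3, between 2.5 and 3.6.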

Compound 4, distribution coefficient: 3
Compound 4: middle estimate and measured number agree at the digits printed; the range from low to high includes it.
By their numbers in this assay, from the lowest: compounds 1 and 2 (each within the scatter of the next); then compounds 3 and 4 (each within the scatter of the next).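

In this assay, the 2-methylpyridin-3-yl group gives a number 0.10 log units higher from compound 3 to compound 4 (within the scatter) so on this aromatic carbon an aromatic six-membered ring and the non-aromatic ring of 1-acetylpiperidin-4-yl read alike. Against the five-membered aromatic rings, the same group gives a number 0.90 log units higher from compound 2 to compound 4 (beyond the scatter) and a number 0.90 log units higher from compound 1 to compound 4 (beyond the scatter) so both six-membered rings stand above both five-membered ones, and none of these four compounds goes against that. Nothing available explains this pattern.

The compounds shown leave open how a free amine or a carboxylic acid would read at this carbon. They also leave open what the methyl of the 2-methylpyridin-3-yl group contributes.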